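Swapping the phenyl halogen on a shared imidazopyrazine core

A few compounds are considered here, and "the series" means these few. Any claim that something is new, unique, unknown or untested is made for them only; others in the source may bear on it.

Compound 1: `c1ccc(-c2cn3ccnc3c(-c3ccc4ncn(C5CCCCC5)c4c3)n2)cc1` — 28.8%
Compound 2: `Clc1ccc(-c2cn3ccnc3c(-c3ccc4ncn(C5CCCCC5)c4c3)n2)cc1` — 13.5%

In a functional assay on SN12C cells (Homo sapiens) for inhibition, read by sulforhodamine B assay, with a stated time of 48 h, tested at 10 uM (a lower number here means less inhibition, a higher number more inhibition at the concentration tested (going by the name of the read-out)), compound 2 gives the lowest of the two numbers; a number 15.3 percentage points lower from compound 1 to compound 2 (beyond the scatter). Compound 3 is `Fc1ccccc1-c1cn2ccnc2c(-c2ccc3ncn(C4CCCCC4)c3c2)n1`. It differs from compound 2 in one place: 2-fluorophenyl in place of 4-chlorophenyl on an aromatic carbon. For the measured compounds named here, only one measured step bears on this change, and only loosely, since it concerns a halogen on the same phenyl: a number 15.3 percentage points lower from compound 1 to compound 2 (beyond the scatter). Going by the values given here, no measured pair shows the swap of one halogen for another or of its place on the phenyl, so a small step is expected, in either direction, a number 6.5 percentage points higher from compound 2 to compound 3 (within the scatter). For compound 3 the estimate is 20%, with a range from 5% to 38%.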

Compound 3, a percentage reported as inhibition, at one concentration (the size of the read-out at that concentration, not a potency): 10.1%
Beside the measured number, compound 3's estimate is 9.9 percentage points above it; measured number inside the range.
By their numbers in this assay, from the lowest: compounds 3 and 2 (each within the scatter of the next); then compound 1.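

In this assay, the swap of 4-chlorophenyl for 2-fluorophenyl gives a number 3.4 percentage points lower from compound 2 to compound 3 (within the scatter), so changing the halogen and its place together does not separate these two compounds. Fluoro in place of hydrogen gives a number 18.7 percentage points lower from compound 1 to compound 3 (beyond the scatter), so both halogen-bearing compounds shown sit apart from the plain phenyl of compound 1. Nothing available explains this result.
On these data alone, because compound 3 changes the halogen and its place at once, their separate contributions stay open. Also open, as far as these compounds go, is how a phenyl carrying an amine or a carboxylic acid would compare.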